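Series notes: aryl variation at the nitrile-bearing position

A few compounds are considered here, and "the series" means these few. Any claim that something is new, unique, unknown or untested is made for them only; others in the source may bear on it.

Measured so far in a functional assay for inhibition, tested at 80 ug/mL; a higher number here means a stronger effect of the compound at the concentration tested, a lower number a weaker effect:
compound 1, `Cc1cc(O)c(C(C)C)cc1-c1cc(-c2ccccc2[N+](=O)[O-])c(C#N)c(=O)[nH]1`, gives 35%
compound 2, `Cc1cc(O)c(C(C)C)cc1-c1cc(-c2ccccc2Cl)c(C#N)c(=O)[nH]1`, gives 32%
compound 3, `COc1cc(-c2cc(-c3cc(C(C)C)c(O)cc3C)[nH]c(=O)c2C#N)ccc1O`, gives 42%

Compound 3 stands at the top of the three numbers, but the steps of a number 7 percentage points higher from compound 1 to compound 3 (within the scatter) and a number 10 percentage points higher from compound 2 to compound 3 (within the scatter) are both within the scatter, as is a number 3 percentage points lower from compound 1 to compound 2 (within the scatter), so the three compounds cannot be separated on these readings.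

Compound 4, `Cc1cc(O)c(C(C)C)cc1-c1cc(-c2ccc(N(C)C)cc2)c(C#N)c(=O)[nH]1`, is the next member, not yet measured. Its change from compound 3 is 4-(dimethylamino)phenyl in place of 4-hydroxy-3-methoxyphenyl on an aromatic carbon. Within the data shown here, no measured step swaps exactly this pair of groups. Among the measured compounds shown here, the steps that bear on it are those that exchanged the aryl group on the same carbon of the shared core, a number 7 percentage points higher from compound 1 to compound 3 (within the scatter) and a number 10 percentage points higher from compound 2 to compound 3 (within the scatter), and both stayed within the scatter. The expectation is therefore a step of a number 6 percentage points lower from compound 3 to compound 4 (within the scatter) in this assay, with no direction beyond the scatter. Compound 4 is estimated at 36%, with a range from 22% to 50%.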

Compound 4, a percentage reported as inhibition, at one concentration (the size of the read-out at that concentration, not a potency): 66.5%
Beside the measured number, compound 4's estimate is 30.5 percentage points below it; the measured number lies above the stated range.
By their numbers in this assay, from the lowest: compounds 2, 1 and 3 (each within the scatter of the next); then compound 4.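

In this assay, the aryl group on this carbon, opposite the ring nitrogen, now shows a clear effect on the read-out, with a modest step of a number 24.5 percentage points higher from compound 3 to compound 4 (beyond the scatter) and large steps of a number 34.5 percentage points higher from compound 2 to compound 4 (beyond the scatter) and a number 31.5 percentage points higher from compound 1 to compound 4 (beyond the scatter), whereas the three earlier aryl groups could not be separated. 4-(Dimethylamino)phenyl therefore stands apart from 4-hydroxy-3-methoxyphenyl, 2-chlorophenyl and 2-nitrophenyl, even though it has the same heavy-atom count as 4-hydroxy-3-methoxyphenyl and differs by having no hydrogen-bond donor and one fewer acceptor. No measurement available here explains why this change gives such a step.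

The compounds shown leave open whether the step depends on the dimethylamino group itself. A phenyl bearing a primary amine or a diethylamino group would bear directly on that question.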